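A few compounds are considered here, and "the series" means these few. Any claim that something is new, unique, unknown or untested is made for them only; others in the source may bear on it.

Compound 1 `O=C(CSc1nc2c(c(=O)n1-c1ccccc1)SCC2)Nc1ccc(N2CCCCC2)cc1` gives 30 nM in an assay on L cells for inhibition of Protein-serine O-palmitoleoyltransferase porcupine (Mus musculus), read by reporter gene assay, with a stated time of 24 h; a lower number here means that less compound is needed, a higher number that more compound is needed for the effect. Compound 2 `COc1ccc(-n2nc(C(=O)NCC(=O)Nc3nc4ccc(Cl)cc4s3)c3ccccc3c2=O)cc1` gives 15 nM. Compound 3 `O=C(CSc1nc2c(c(=O)n1-c1ccccc1)SCC2)Nc1ccc(-c2ccccc2)cc1` gives 0.75 nM, the lowest of the three numbers, and its distance from compound 2 and from compound 1 lies beyond the usual scatter in each case. Among the compounds with values here, the one measured single change, a 40-fold lower number from compound 1 to compound 3 (1.60 log units; beyond the scatter), shows how strongly the group at this position can move the number. Compound 4 `O=C(CSc1nc2c(c(=O)n1-c1ccccc1)SCC2)Nc1ccc(-c2ccncc2)cc1` differs from compound 3 by a single change: pyridin-4-yl in place of phenyl on an aromatic carbon. Within the data shown here, no measured step exchanges phenyl for pyridin-4-yl, so the step from compound 1 to compound 3 tells only that this position is sensitive, not which way this smaller change will go. The expected step, a 1.3-fold higher number from compound 3 to compound 4 (0.12 log units; within the scatter), is therefore small. Compound 4 is estimated at 1 nM, within a range from 0.25 nM to 5 nM.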

Compound 4, half-maximal effective concentration: 3 nM
Compound 4: middle estimate off by 3.0-fold (0.48 log units), on the low side; low and high end bracket the measured number.
By their numbers in this assay, from the lowest: compound 3; then compound 4; then compounds 2 and 1 (each within the scatter of the next).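

Exchanging phenyl for pyridin-4-yl keeps the count of heavy atoms and adds one hydrogen-bond acceptor, yet it gives a 4.0-fold higher number from compound 3 to compound 4 (0.60 log units; beyond the scatter), so this position responds even to a single ring nitrogen. Pyridin-4-yl still compares well with piperidin-1-yl, as a 10-fold lower number from compound 1 to compound 4 (1.00 log units; beyond the scatter) shows, so an aromatic ring here gives a lower number in both cases. No available data explain either step. The compounds shown leave open how pyridin-3-yl, or a phenyl ring carrying an amine or a carboxylic acid, would compare at this place.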